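Para substituent swap on the N-aryl ring: chloro for methoxy

The compounds below may be only part of what the source reports. "The series", "measured", "known", "first", "only" and "open" are said of these compounds alone.

Measured so far:
compound 1, `COc1cc2c(Oc3ccc(NC(=O)c4nn(-c5ccccc5C)c(=O)cc4C)cc3F)ccnc2cc1OCCCN1CCC(C)CC1`, 2810 nM in a functional assay on HT-29 cells (Homo sapiens) for inhibition, read by MTT assay, with a stated time of 72 h; a lower number here means a stronger inhibitor, a higher number a weaker inhibitor
compound 2, `COc1ccc(-n2nc(C(=O)Nc3ccc(Oc4ccnc5cc(OCCCN6CCC(C)CC6)c(OC)cc45)c(F)c3)c(C)cc2=O)cc1`, 5450 nM in this assay

Going by the values given here, compound 2 stands at the higher of the two numbers measured in this assay; its only neighbour is compound 1, and the step of a 1.9-fold higher number from compound 1 to compound 2 (0.29 log units; within the scatter) is within the scatter, so the two are not separated by these data.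

Compound 3, `COc1cc2c(Oc3ccc(NC(=O)c4nn(-c5ccc(Cl)cc5)c(=O)cc4C)cc3F)ccnc2cc1OCCCN1CCC(C)CC1`, differs from compound 2 in one place: chloro in place of methoxy on an aromatic carbon. Among the compounds with values here, no measured step involves a chloro or methoxy group at this position; the only step in hand, a 1.9-fold higher number from compound 1 to compound 2 (0.29 log units; within the scatter), concerns a different group on the same ring and was itself within the scatter. The change is therefore taken as likely to shift this assay by little, with no direction established beyond the scatter.

The estimate for compound 3 in this assay is 4000 nM, with a range from 1500 nM to 11000 nM, which means an expected step of a 1.4-fold lower number from compound 2 to compound 3 (0.13 log units; within the scatter).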

Compound 3, half-maximal inhibitory concentration: 180 nM
Compound 3: the middle estimate sits 22-fold (1.35 log units) above what was measured, outside the stated range (below it).
By their numbers in this assay, from the lowest: compound 3; then compounds 1 and 2 (each within the scatter of the next).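

The aromatic carbon para to a large group on this ring is far from silent in this assay: chloro in place of methoxy gives a 30-fold lower number from compound 2 to compound 3 (1.48 log units; beyond the scatter) and stands beyond the scatter, whereas the earlier change on this ring did not. The 4-chlorophenyl group also separates clearly from the 2-methylphenyl group, with a 16-fold lower number from compound 1 to compound 3 (1.19 log units; beyond the scatter) on the same shared core, so compound 3 stands apart from two compounds that these data could not separate from each other. No measured evidence bears on the reason for either step.

The compounds shown leave open whether the large step follows the arrival of chloro in particular or the departure of methoxy. Also open, on these data alone, is how bromo, trifluoromethyl or an amine at the same place would read in this assay on this series.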